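Working notes on compounds 1 to 3

A few compounds are considered here, and "the series" means these few. Any claim that something is new, unique, unknown or untested is made for them only; others in the source may bear on it.

Measured so far:
Compound 1, `COc1cc(Cl)cc(-c2nn(-c3cccc(NC(=O)c4ccc(Cl)c(Cl)c4)c3)cc2-c2ccncc2)c1`, gives 59.2% in a functional assay on CCRF-CEM cells (Homo sapiens) for inhibition, read by sulforhodamine B assay, with a stated time of 48 h, tested at 10 uM; on this read-out lower numbers stand for a stronger effect and higher numbers for a weaker effect at the one concentration tested.
Compound 2, `O=C(Nc1cccc(-n2cc(-c3ccncc3)c(-c3cc(O)cc(Cl)c3)n2)c1)Nc1ccc(Cl)c(C(F)(F)F)c1`, gives 9.31% in this assay.

Of the two numbers in hand, compound 2 stands lowest, and compound 1 is its nearest neighbour, a number higher by a margin beyond the usual scatter. Going by the values given here, compounds 1 and 2 differ in more than one place, so the two values show only that compound 2 sits at the stronger end of the pair and compound 1 at the weaker end; no single change can be read from them.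

Compound 3, `O=C(Nc1cccc(-n2cc(-c3ccncc3)c(-c3cc(O)cc(Cl)c3)n2)c1)Nc1ccc(Cl)c(Cl)c1`, is the next point and is still to be measured in this assay. It differs from compound 2 in one place: chloro in place of trifluoromethyl on an aromatic carbon. Both groups are small, uncharged, and carry no hydrogen-bond donor or acceptor, and the change sits at the same position on the same ring. Among the compounds with values here, with no measured step of this kind to lean on, the expected step from compound 2 to compound 3 is a number 4.7 percentage points higher from compound 2 to compound 3 (within the scatter), that is, none beyond the scatter, if anything a slight drift upward. Compound 3 is therefore estimated at 14%, with a range from 4% to 38%, the upper end allowing for the step turning out larger than expected.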

Compound 3, a percentage reported as activity, at one concentration (the size of the read-out at that concentration, not a potency): 4.11%
Estimate against measurement, compound 3: 9.9 percentage points above; low and high end bracket the measured number.
By their numbers in this assay, from the lowest: compounds 3 and 2 (each within the scatter of the next); then compound 1.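

In this assay, going by these compounds alone, replacing trifluoromethyl with chloro on this aromatic carbon gives a number 5.2 percentage points lower from compound 2 to compound 3 (within the scatter) and is the first one-place change available. At this place, ortho to a chloro group and meta to a large group, the read-out therefore does not separate the 4-chloro-3-(trifluoromethyl)phenyl group from the 3,4-dichlorophenyl group, even though the group leaving has 4 heavy atoms and the group entering has 1. No measurement on these compounds offers a reason for this outcome.

As far as these compounds go, the two groups compared here carry no charge and no hydrogen-bond donors or acceptors, so it remains open whether an amine, a carboxylic acid or a longer alkyl chain at the same place would keep the read-out within the scatter of compound 3 at 4.11% in this assay or shift it beyond that scatter. Also open, from the compounds shown here alone, is how the other differences between compound 1 and compound 3 contribute, since these compounds differ in more than one place and no single change can be read from them.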